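This account rests on a few compounds, and the source may have more. Where it says the series, first, only, none or still open, it means among the compounds named here.

Measured so far:
- compound 1, `CCCCNc1nc(N)nc2c1CN(C)CC2`: 0.03 uM
- compound 2, `CCCCNc1nc(N)nc2c1CN(C(=O)c1ccccc1)CC2`: 1.4 uM
- compound 3, `CCCCNc1nc(N)nc2c1CN(S(C)(=O)=O)CC2`: 9.9 uM

All three were tested in an assay on HEK293 cells for agonist activity at Toll-like receptor 8 (Homo sapiens), read by a luciferase reporter, with a stated time of 6 h; a higher number here means that more compound is needed for the effect, a lower number that less compound is needed. Compound 1 gives the lowest number of the three; compound 2 sits nearest, by a 47-fold higher number from compound 1 to compound 2 (1.67 log units; beyond the scatter), and compound 3 is furthest, by a 330-fold higher number from compound 1 to compound 3 (2.52 log units; beyond the scatter). Between those two, a 7.1-fold higher number from compound 2 to compound 3 (0.85 log units; beyond the scatter).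

Compound 4 is `CCCCNc1nc(N)nc2c1CN(Cc1c(Cl)cccc1Cl)CC2`. It differs from compound 1 in one place: 2,6-dichlorophenyl in place of hydrogen on a saturated chain carbon bound to an amine nitrogen in a ring. The ring nitrogen itself is left as it is; the new group is attached to the carbon already bound to that nitrogen.

The two measured steps that touch this part of the molecule, from compound 1 to compound 2 and from compound 1 to compound 3, both swapped the methyl on the ring nitrogen for a different group and both gave large rises in this assay. Compound 4 keeps that carbon on the nitrogen and only adds to it, so those steps are a loose guide at best. Some rise in the number is expected, but a smaller one than either measured step, with a 4.0-fold higher number from compound 1 to compound 4 (0.60 log units; beyond the scatter) as the estimate. Compound 4 is therefore estimated at 0.12 uM, within a range from 0.02 uM to 0.7 uM.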

Compound 4, minimum effective concentration: 0.14 uM
Compound 4: the middle estimate sits 1.2-fold (0.07 log units) below what was measured, within the range that was stated.
By their numbers in this assay, from the lowest: compound 1; then compound 4; then compound 2; then compound 3.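

In this assay, the carbon bound to the ring amine nitrogen can carry a much larger group than hydrogen: adding 2,6-dichlorophenyl, with its 8 heavy atoms, gives a 4.7-fold higher number from compound 1 to compound 4 (0.67 log units; beyond the scatter), a real but modest rise. The earlier steps shown here, a 47-fold higher number from compound 1 to compound 2 (1.67 log units; beyond the scatter) and a 330-fold higher number from compound 1 to compound 3 (2.52 log units; beyond the scatter), replaced the methyl on that nitrogen and produced large rises, whereas this change keeps the carbon in place and produces a smaller one, so the size of the added group alone does not set the size of the rise across these steps. What lies behind this difference cannot be said, as no measurement here bears on the cause.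

A plain phenyl group in the same place would show how much of the rise belongs to the ring and how much to its two chlorine atoms. Whether a small amine or a carboxylic acid on that carbon would be accepted equally well, or would move the number further from that of compound 1, remains an open question.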